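A few compounds are considered here, and "the series" means these few. Any claim that something is new, unique, unknown or untested is made for them only; others in the source may bear on it.

Working notes on the series. Compound 1 `Cc1ccc(-c2nc(CNc3ccc(C(=O)NO)cc3)n(-c3ccccc3)n2)cc1` and compound 2 `Cc1cccc(-n2nc(-c3ccccc3)nc2CNc2ccc(C(=O)NO)cc2)c1` share a core and differ in where the methyl sits and which aromatic ring carries it. In a functional assay on MGC-803 cells (Homo sapiens) for antiproliferative activity, read by MTT assay, with a stated time of 72 h (a lower number here means a stronger inhibitor, a higher number a weaker inhibitor), compound 1 gives > 20000 nM, which is a limit of the assay and not a number. Going by these compounds, compound 1 therefore stands at the limit of > 20000 nM in this assay, at which 1 of the 2 values shown sits, so its true potency is unknown beyond that. Compound 2 gives 13200 nM in this assay, a measured number. Since compound 1 has only a limit, nothing can be said about the size of any gap between them.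

Compound 3 `O=C(NO)c1ccc(NCc2nc(-c3ccc(Cl)cc3)nn2-c2ccccc2)cc1` is the next analogue. It differs from compound 1 by chloro in place of methyl on an aromatic carbon. For the measured compounds named here, no measured pair shares this change, so the size of the step is not known from data; with compound 1 at a limit, the step from compound 1 to compound 3 is expected to be small, with no direction that can be called beyond the scatter, and the expected step is an at least 1.3-fold lower number from compound 1 to compound 3 (0.12 log units; that floor lies within the scatter). For compound 3 the expected value in this assay is 15000 nM, within 5000 nM to 45000 nM.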

Compound 3, half-maximal inhibitory concentration: 5970 nM
Compound 3: middle estimate off by 2.5-fold (0.40 log units), on the high side; the range from low to high includes it.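

In this assay, the change from 4-methylphenyl to 4-chlorophenyl gives an at least 3.3-fold lower number from compound 1 to compound 3 (0.52 log units; beyond the scatter), so this place on the six-membered aromatic ring, para to a large group, responds to the swap by more than the scatter. For the compounds shown here, this is the first single-place step that can be read, as compound 1 and compound 2 differ in more than one place and gave none. Compound 1 holds a limit of the assay and not a number, so the step is a floor and its true size remains unknown: the limit of > 20000 nM in this assay, at which 1 of the 3 values shown sits.

The compounds shown leave open how this place responds to other groups, such as fluoro, methoxy, trifluoromethyl or nitrile, and whether a plain hydrogen there would read closer to methyl or to chloro. They also leave open whether chloro in place of methyl holds its direction on the other aromatic ring, the phenyl that carries the methyl in compound 2, and a single step cannot tell what in the change lies behind the lower number.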